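Swapping Bromo for Iodo: Three Measured Points, One Unknown

The compounds below may be only part of what the source reports. "The series", "measured", "known", "first", "only" and "open" are said of these compounds alone.

Three compounds share one core and differ only in the group on the phenoxy ring: compound 1 `O=C(Oc1ccccc1)c1cc2cc([N+](=O)[O-])ccc2oc1=O`, compound 2 `O=C(Oc1cccc(Cl)c1)c1cc2cc([N+](=O)[O-])ccc2oc1=O` and compound 3 `O=C(Oc1cccc(Br)c1)c1cc2cc([N+](=O)[O-])ccc2oc1=O`. In a functional assay on HT-1080 cells (Homo sapiens), read by transwell migration, with a stated time of 24 h, tested at 1 uM (a higher number here means a weaker effect of the compound at the concentration tested, a lower number a stronger effect), compound 1 gives 76.7%, compound 2 gives 65.8%, and compound 3 gives 35.2%, the lowest of the three numbers and beyond the scatter from both others. The steps between them all run the same way: a number 10.9 percentage points lower from compound 1 to compound 2 (beyond the scatter), a number 41.5 percentage points lower from compound 1 to compound 3 (beyond the scatter) and a number 30.6 percentage points lower from compound 2 to compound 3 (beyond the scatter). Compound 4 `O=C(Oc1cccc(I)c1)c1cc2cc([N+](=O)[O-])ccc2oc1=O` carries the next change in this series: iodo in place of bromo on an aromatic carbon. The step from chloro to bromo bears most directly on it and was large, while the step from hydrogen to chloro was modest. A further fall beyond the scatter is therefore expected, though a smaller one, since the number already stands low. The change is expected to read a number 13.2 percentage points lower from compound 3 to compound 4 (beyond the scatter). Compound 4 is estimated to give 22% in this assay, within a range from 8% to 42%.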

Compound 4, a percentage reported as activity, at one concentration (the size of the read-out at that concentration, not a potency): 63.6%
For compound 4 the middle estimate is 41.6 percentage points below the measured one; the whole stated range lies below it.
By their numbers in this assay, from the lowest: compound 3; then compounds 4 and 2 (each within the scatter of the next); then compound 1.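

In this assay the change from bromo to iodo runs against every earlier step, giving a number 28.4 percentage points higher from compound 3 to compound 4 (beyond the scatter) and showing that the low number of compound 3 does not carry over to the next halogen. Iodo and chloro cannot be told apart at this place on the ring, with a number 2.2 percentage points lower from compound 2 to compound 4 (within the scatter) in this assay, so among these halogens bromo alone stands apart. Iodo still counts against plain hydrogen, with a number 13.1 percentage points lower from compound 1 to compound 4 (beyond the scatter), so all three halogens shown read lower than the unsubstituted compound 1.

From the compounds shown here alone, whether another group at this place, such as a methoxy or an amine, could reach the number of compound 3 remains open. Nothing measured here explains why bromo stands apart from chloro and iodo.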